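Halogen swap on the anilide ring of compound 1

This account rests on a few compounds, and the source may have more. Where it says the series, first, only, none or still open, it means among the compounds named here.

Compound 1 `COc1ccc(-n2ccnc2SCC(=O)Nc2ccccc2Br)cc1` sits at the top of the set shown: in an ADME assay on MT4 cells (Homo sapiens) for cytotoxicity, read by MTT assay (a lower number here means that less compound is tolerated, a higher number that more compound is tolerated), compound 1 gives only a limit, > 298000 nM, and the reading the limit of > 298000 nM in this assay, at which 1 of the 3 values shown sits, is that limit rather than a number. Compound 2 `Cc1ccc(-n2ccnc2SCC(=O)Nc2ccccc2Br)cc1` gives 39300 nM, and compound 3 `Cc1ccc(NC(=O)CSc2nccn2-c2cccc3ccccc23)c(Br)c1` gives 29400 nM. Among the compounds with values here, the one measured step, an at least 7.5-fold lower number from compound 1 to compound 2 (0.87 log units; beyond the scatter), concerns a different part of the molecule. Within the data shown here, compound 4 `COc1ccc(-n2ccnc2SCC(=O)Nc2ccccc2F)cc1` differs from compound 1 by fluoro in place of bromo on an aromatic carbon; no measured step touches this change, so no step beyond the scatter is expected in this assay from it. Compound 4 is therefore expected to stay near the limit, at 300000 nM, between 100000 nM and 450000 nM. The expected step is a step that the limit leaves unreadable from compound 1 to compound 4.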

Compound 4, half-maximal cytotoxic concentration: >= 41900 nM
Compound 4: a limit, no number (the forecaster's own chance of this, stated with the estimate: 60%); the middle value does not contradict the limit.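

In this assay compound 1 and compound 4 both give limits rather than numbers, and the step between them cannot be read. The compounds shown leave open whether fluoro in place of bromo shifts the half-maximal cytotoxic concentration at all.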